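The compounds below may be only part of what the source reports. "The series", "measured", "known", "first", "only" and "open" are said of these compounds alone.

In a functional assay on HCT-116 cells (Homo sapiens) for cytotoxicity, read by MTT assay, with a stated time of 72 h (a higher number here means a weaker inhibitor, a lower number a stronger inhibitor), compound 1 `Nc1ccc(Nc2c(C(=O)NCc3ccc(F)cc3)nc(Br)c3cccnc23)cc1` gives 7000 nM. Compound 2 `NCCNc1c(C(=O)NCc2ccc(F)cc2)nc(Br)c2cccnc12` gives > 20000 nM, which is a limit of the assay and not a number. In compound 3 `CNc1c(C(=O)NCc2ccc(F)cc2)nc(Br)c2cccnc12`, hydrogen takes the place of aminomethyl on a saturated chain carbon bound to a nitrogen on an aromatic ring (hydrogen in place of aminomethyl on a saturated chain carbon bound to a nitrogen on an aromatic ring), so 2-aminoethyl becomes methyl. For the measured compounds named here, the one measured step bearing on this is an at least 2.8-fold higher number from compound 1 to compound 2 (0.45 log units; beyond the scatter), which swaps 4-aminophenyl for 2-aminoethyl. Like compound 2, compound 3 lacks the 4-aminophenyl of compound 1, which gives 7000 nM, so no step beyond the scatter is expected in this assay. The expected step is a number no higher from compound 2 to compound 3 (the limit leaves the size open). Compound 3 is estimated at 20000 nM, with an expected range of 9000 nM to 45000 nM.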

Compound 3, half-maximal inhibitory concentration: > 20000 nM
Compound 3: no number, only a limit; the forecaster's own chance of this, stated with the estimate: 60%; the middle value sits exactly at the limit.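

In this assay, methyl in place of 4-aminophenyl on a nitrogen on an aromatic ring gives an at least 2.8-fold higher number from compound 1 to compound 3 (0.45 log units; beyond the scatter). So the small methyl, like the 2-aminoethyl of compound 2, falls short of 4-aminophenyl here, with or without the chain's amine. The step between compound 2 and compound 3 cannot be read, because both are limits and not numbers: the limit of > 20000 nM in this assay, at which 2 of the 3 values shown sit.

Still open, as far as these compounds go, is whether a plain phenyl, without its amine, would match compound 1, or whether the aromatic ring and the amine are both needed. A longer chain ending in an amine is equally untested among these compounds.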